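Swapping the bicyclic heteroaryl amide in a sulfonyl benzylamide series

A few compounds are considered here, and "the series" means these few. Any claim that something is new, unique, unknown or untested is made for them only; others in the source may bear on it.

Of the compounds shown here, three of one series have been measured in an ADME assay on microsomes from liver (Homo sapiens) for metabolic stability, read by LC-MS, with a stated time of 30 min, tested at 1 uM; a higher number here means that more of the compound is left, a lower number that less of the compound is left. Compound 1, `O=C(NCc1ccc(S(=O)(=O)N2CCCCC2)cc1)c1ccn2cncc2c1`, gives 54% in this assay, which is the lowest of the three numbers; compound 3, `O=C(NCc1ccc(S(=O)(=O)c2ccccc2)cc1)c1cn2ccnc2cn1`, gives 87%, and compound 2, `O=C(NCc1ccc(S(=O)(=O)c2ccccc2)cc1)c1ccc2nncn2c1`, gives 96%, both of them beyond the scatter above compound 1. Compounds 2 and 3 differ from compound 1 in two places at once, so their distance from it cannot be assigned to either part. Among the measured compounds shown here, the one clean step among them is the exchange of the heteroaryl on the carbonyl carbon, a number 9 percentage points lower from compound 2 to compound 3 (within the scatter).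

Compound 4, `O=C(NCc1ccc(S(=O)(=O)N2CCCCC2)cc1)c1cc2ccncc2o1`, keeps the sulfonamide side of compound 1 and changes only the heteroaryl: a group of 9 heavy atoms (7 carbon, 1 nitrogen, 1 oxygen; one five-membered aromatic ring with 1 hetero atom, one six-membered aromatic ring with 1 hetero atom) in place of a group of 9 heavy atoms (7 carbon, 2 nitrogen; one five-membered aromatic ring with 2 hetero atoms, one six-membered aromatic ring with 1 hetero atom), on a carbonyl carbon. For the measured compounds named here, the step from compound 2 to compound 3 is the only comparison of that kind available, and it stayed within the scatter; nothing among the three compounds shows such a swap on the carbonyl carbon moving this assay beyond the scatter. Compound 4 is therefore expected to show a number 1 percentage points higher from compound 1 to compound 4 (within the scatter), with the middle of the estimate near the value of compound 1. For compound 4 the estimate is 55%, between 35% and 75%.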

Compound 4, percent of the compound remaining: 56%
Beside the measured number, compound 4's estimate is 1 percentage points below it, and the stated range covers the measured number.
By their numbers in this assay, from the lowest: compounds 1 and 4 (each within the scatter of the next); then compounds 3 and 2 (each within the scatter of the next).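

The exchange of the heteroaryl on the carbonyl carbon, now made on the sulfonamide side of the series, gives a number 2 percentage points higher from compound 1 to compound 4 (within the scatter) in this assay. Among the compounds shown here, the earlier step, a number 9 percentage points lower from compound 2 to compound 3 (within the scatter), came from compounds that keep much more of their material, so the two within-scatter steps together show that such swaps at this place leave the number in place at both the upper and the lower end of the values seen, with no compound here going against that. This also holds for a change that puts a five-membered aromatic ring with 1 hetero atom, oxygen among its atoms, in place of one with 2 hetero atoms, and no information is available on the cause of this result.

No pair shown carries the same heteroaryl with both the sulfonamide and the phenyl sulfone side, so the gap between compound 1 and compound 2 cannot be assigned to either part. On these data alone, whether this place would stay as quiet with a heteroaryl bearing an amine or a carboxylic acid, or with a plain phenyl on the carbonyl carbon, also remains open.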